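Extending the Amine Chain on a Shared Core

The source may hold more compounds than are shown below. What is called first, only, known or untested is meant among the compounds shown, and "the series" means these compounds.

Of the compounds shown here, three sharing one core have been measured in an assay on cell membranes for displacement of a labelled ligand from corticotropin-releasing factor receptor 1 (Rattus norvegicus); on this read-out higher numbers stand for weaker inhibition and lower numbers for stronger inhibition. Compound 1 `CCCN(CCC)c1nc(C)nc2c(-c3ccc(OC)nc3C)c(C)nn12` gives 5.7 nM. Compound 2 `CCCC(C)Nc1nc(C)nc2c(-c3ccc(OC)nc3C)c(C)nn12` gives 3.5 nM, and compound 3 `CCCCN(CC)c1nc(C)nc2c(-c3ccc(OC)nc3C)c(C)nn12` gives 4.9 nM. Compound 3 stands second highest of the three numbers, with compound 1 nearest and compound 2 furthest, yet every step among them lies within the scatter: a 1.6-fold lower number from compound 1 to compound 2 (0.21 log units; within the scatter), a 1.2-fold lower number from compound 1 to compound 3 (0.07 log units; within the scatter) and a 1.4-fold higher number from compound 2 to compound 3 (0.15 log units; within the scatter). Compound 4 `CCCCN(CCC)c1nc(C)nc2c(-c3ccc(OC)nc3C)c(C)nn12` has not yet been measured in this assay. It differs from compound 3 by methyl in place of hydrogen on a saturated chain carbon, two bonds along the chain from a nitrogen on an aromatic ring. Among the measured compounds shown here, the steps that bear on this change are the three just given, each of which varies the substituent on the same aromatic carbon, and none of which moves the number beyond the scatter. The change from compound 3 to compound 4 again varies only that substituent, so the expected step in this assay is one of no more than scatter size, with no clear direction: a 1.1-fold lower number from compound 3 to compound 4 (0.04 log units; within the scatter). Compound 4 is therefore estimated at 4.5 nM, within a range from 2 nM to 10 nM.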

Compound 4, half-maximal inhibitory concentration: 2.4 nM
For compound 4 the middle estimate is 1.9-fold (0.27 log units) above the measured one; the range from low to high includes it.
By their numbers in this assay, from the lowest: compounds 4, 2, 3 and 1 (each within the scatter of the next, the first and the last beyond it).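

Extending the ethyl of compound 3 to propyl, with methyl in place of hydrogen on a saturated chain carbon, two bonds along the chain from a nitrogen on an aromatic ring, moves the number beyond the scatter in this assay, which none of the steps among compounds 1, 2 and 3 did: a 2.0-fold lower number from compound 3 to compound 4 (0.31 log units; beyond the scatter), a modest step, and the same butyl(propyl)amino group also separates from the dipropylamino of compound 1, with a 2.4-fold lower number from compound 1 to compound 4 (0.38 log units; beyond the scatter), again modest. The (1-methylbutyl)amino group of compound 2 is not separated from this group, since a 1.5-fold lower number from compound 2 to compound 4 (0.16 log units; within the scatter) stays within the scatter, so the tertiary butyl(propyl)amino group cannot be ranked against that secondary amine. No measurement is at hand that would explain why the added methyl shifts the number at this position.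

Going by these compounds, whether the trend continues, levels off or reverses with dibutylamino or a longer chain such as pentyl on the same nitrogen stays open. Also open, on these data alone, is whether the step from ethyl to propyl would hold on a core carrying another group, such as chlorine, in place of the methoxy.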